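The compounds below may be only part of what the source reports. "The series", "measured", "known", "first", "only" and "open" are said of these compounds alone.

Measured in a functional assay on B16 cells (Mus musculus) for antiproliferative activity, read by MTT assay, with a stated time of 24 h; a higher number here means a weaker inhibitor, a lower number a stronger inhibitor:
Compound 1 `COc1cc(OC)c(-c2coc3cc(OCC(=O)c4cccc(C(F)(F)F)c4)ccc3c2=O)cc1OC`: > 10000 nM (a limit of the assay)
Compound 2 `COc1cc(OC)c(-c2coc3cc(OCc4cccc(Br)c4)ccc3c2=O)cc1OC`: 4400 nM
Compound 3 `COc1cc(OC)c(-c2coc3cc(OCc4ccccc4Br)ccc3c2=O)cc1OC`: 8900 nM

Compound 3 (8900 nM) has the higher of the two actual numbers. Compound 1 gives only a limit.

Compound 4 `COc1cc(OC)c(-c2coc3cc(OCc4ccc(C(F)(F)F)cc4)ccc3c2=O)cc1OC` has 4-(trifluoromethyl)phenyl in place of 2-bromophenyl on a saturated chain carbon bound to an oxygen on an aromatic ring. Within the data shown here, no measured step makes this exchange. The nearest evidence is the modest 2.0-fold higher number from compound 2 to compound 3 (0.31 log units; beyond the scatter) between the two bromophenyl groups. The steps of an at least 2.2-fold lower number from compound 1 to compound 2 (0.35 log units; beyond the scatter) and an at least 1.1-fold lower number from compound 1 to compound 3 (0.05 log units; that floor lies within the scatter) start from a limit and replace a different group. Going by these compounds, no step beyond the scatter is therefore expected in this assay, and the direction stays open. The expected step is a 1.4-fold lower number from compound 3 to compound 4 (0.14 log units; within the scatter) on this estimate. For compound 4 the estimated value is 6500 nM, with an expected range of 2500 nM to 15000 nM.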

Compound 4, half-maximal inhibitory concentration: 5400 nM
Estimate against measurement, compound 4: 1.2-fold (0.08 log units) above; measured number inside the range.
By their numbers in this assay, from the lowest: compounds 2, 4 and 3 (each within the scatter of the next, the first and the last beyond it). At a limit, above all of these: compound 1.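

In this assay 4-(trifluoromethyl)phenyl on the saturated chain carbon gives a 1.6-fold lower number from compound 3 to compound 4 (0.22 log units; within the scatter) and a 1.2-fold higher number from compound 2 to compound 4 (0.09 log units; within the scatter) and both steps lie within the scatter. Compound 4 therefore separates from neither bromophenyl compound, although compound 2 and compound 3 lie beyond the scatter of each other. Compound 1 stands at a limit: the limit of > 10000 nM in this assay, at which 1 of the 4 values shown sits. The step from that limit is only a floor: an at least 1.8-fold lower number from compound 1 to compound 4 (0.26 log units; that floor lies within the scatter).

Open, going by these compounds, is what an amine or a carboxylic acid on the phenyl ring would give. On these data alone, a longer chain in place of the saturated chain carbon is equally open.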